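The source may report more compounds than this note shows. Statements on the series, on what has been measured and on what is new or still open speak of the compounds shown alone.

Working notes on the series in a functional assay on NSCLC cells (Homo sapiens) for antiproliferative activity; on this read-out higher numbers stand for weaker inhibition of growth and lower numbers for stronger inhibition of growth.

Of the compounds shown here, three have numbers so far. Compound 1 `Cc1cn2c(/C=N/NC(=N)N)c(-c3ccncc3)nc2s1` gives 33100 nM and stands second highest of the three. Nearest to it is compound 3 `N=C(N)N/N=C/c1c(-c2ccncc2)nc2sc(Cl)cn12`, which gives 17000 nM; the step of a 1.9-fold lower number from compound 1 to compound 3 (0.29 log units; within the scatter) is within the scatter. Furthest is compound 2 `N=C(N)N/N=C/c1c(-c2cc([N+](=O)[O-])c(Cl)cc2Cl)nc2sc(Cl)cn12`, which gives 72400 nM; compound 2 differs from compound 3 in more than one place, so its value is set beside the others without a step of its own.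

Compound 4 `Cc1cn2c(/C=N/NC(=N)N)c(-c3ccccn3)nc2s1` is the next member to be measured. It differs from compound 1 in one place: pyridin-2-yl in place of pyridin-4-yl on an aromatic carbon. For the measured compounds named here, none of the measured steps touches this change; the only step measured, from compound 1 to compound 3, varies the substituent on the five-membered ring and stays within the scatter, and no pair shows the effect of moving the ring nitrogen of the pyridyl group. For compound 4 the expectation is therefore a step of a 1.1-fold higher number from compound 1 to compound 4 (0.02 log units; within the scatter) of no size beyond the scatter, in no set direction. The estimated value for compound 4 in this assay is 35000 nM, with a range from 9000 nM to 140000 nM.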

Compound 4, concentration for total growth inhibition: 32400 nM
Compound 4: the middle estimate sits 1.1-fold (0.03 log units) above what was measured; the measured number falls inside the stated range.
By their numbers in this assay, from the lowest: compounds 3, 4 and 1 (each within the scatter of the next); then compound 2.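

In this assay, for the compounds shown here, the step of a 1.0-fold lower number from compound 1 to compound 4 (0.01 log units; within the scatter) is the only measured change at this aromatic carbon, and it lies within the scatter. With the rest of compound 1 held fixed, pyridin-2-yl and pyridin-4-yl, the same atoms joined differently, cannot be told apart on this read-out, a finding that holds for this pair alone. No measured property of either compound bears on this result, so nothing can be said about what lies behind it.

On these data alone, it remains open whether a phenyl group, with no ring nitrogen, or a saturated amine such as morpholine at this aromatic carbon would give a step beyond the scatter. As far as these compounds go, it also remains open whether pyridin-2-yl and pyridin-4-yl would stay within the scatter of each other on the core of compound 3, which carries chloro in place of methyl.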